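Three tolerated compounds and a fluorophenyl analogue

This account rests on a few compounds, and the source may have more. Where it says the series, first, only, none or still open, it means among the compounds named here.

Measured compounds:
compound 1 `COc1ccc(CSc2nc(O)c(C)c(Cc3c(Cl)cccc3Cl)n2)c(OC)c1` gives > 55000 nM
compound 2 `Cc1c(O)nc(SCc2ccc(C#N)cc2)nc1Cc1c(Cl)cccc1Cl` gives > 60000 nM
compound 3 `Cc1c(O)nc(S(=O)(=O)Cc2ccc(Br)cc2)nc1Cc1c(Cl)cccc1Cl` gives > 50000 nM

In a functional assay on MT4 cells (Homo sapiens) for cytotoxicity, read by MTT assay (a higher number here means that more compound is tolerated, a lower number that less compound is tolerated), compound 1 reaches only > 55000 nM, which is a limit of the assay and not a number. Compound 2 likewise gives > 60000 nM in this assay, again a limit. Compound 3 gives > 50000 nM in this assay, once more a limit. Compound 2 therefore stands nowhere that can be ranked: its value is a limit, and the two other values shown are limits as well, sitting at the limit of > 50000 nM in this assay, at which 1 of the 3 values shown sits, at the limit of > 55000 nM in this assay, at which 1 of the 3 values shown sits, and at the limit of > 60000 nM in this assay, at which 1 of the 3 values shown sits. Going by the values given here, no step between two measured compounds is available, so nothing here tells how any change in the group on the saturated chain carbon bound to a sulfur shifts this assay.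

Compound 4 `Cc1c(O)nc(SCc2cccc(F)c2)nc1Cc1c(Cl)cccc1Cl` has not yet been measured. It differs from compound 2 by 3-fluorophenyl in place of 4-cyanophenyl on a saturated chain carbon bound to a sulfur. Among the compounds with values here, with three limits and no measured step, the expectation is no movement beyond the scatter, and most likely a further limit. For compound 4 the estimate in this assay is 60000 nM, within 30000 nM to 120000 nM. The step this estimate implies is a number no higher from compound 2 to compound 4 (the limit leaves the size open), expected to be no real change.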

Compound 4, half-maximal cytotoxic concentration: > 61000 nM
Compound 4 ended at the assay's limit; the forecaster's own chance of this, stated with the estimate: 85%; middle value at least 1.0-fold (0.00 log units) away from the limit.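

In this assay compound 4 gives > 61000 nM, which is a limit of the assay and not a number. Compound 2 also stands at a limit, so the step from compound 2 to compound 4 cannot be read. The compounds shown leave open at what concentration any of them becomes cytotoxic, and whether 3-fluorophenyl in place of 4-cyanophenyl on a saturated chain carbon bound to a sulfur shifts this assay at all.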